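From 3-bromophenyl to 2,4-dichlorophenyl on the sulfonyl sulfur

The source may report more compounds than this note shows. Statements on the series, on what has been measured and on what is new or still open speak of the compounds shown alone.

Measured in a functional assay on DLD-1 cells (Homo sapiens) for antiproliferative activity, read by CellTiter-Glo, with a stated time of 72 h; on this read-out higher numbers stand for weaker inhibition and lower numbers for stronger inhibition:
Compound 1 `CC1CCN(C2CCN(S(=O)(=O)c3cccnc3Cl)CC2)CC1`: > 5000 nM, a limit of the assay
Compound 2 `CC1CCN(C2CCN(S(=O)(=O)c3ccc(Br)c(Cl)c3)CC2)CC1`: 12 nM
Compound 3 `CC1CCN(C2CCN(S(=O)(=O)c3cccc(Br)c3)CC2)CC1`: 3.2 nM

Among the measured compounds shown here, compound 3 holds the lowest number among the two exact values, and the only other exact value is that of compound 2 at 12 nM. Compound 4 `CC1CCN(C2CCN(S(=O)(=O)c3ccc(Cl)cc3Cl)CC2)CC1` carries 2,4-dichlorophenyl in place of 3-bromophenyl on a sulfonyl sulfur. For the measured compounds named here, two measured steps bear on this change: the modest 3.8-fold lower number from compound 2 to compound 3 (0.57 log units; beyond the scatter) and the large at least 1500-fold lower number from compound 1 to compound 3 (3.19 log units; beyond the scatter). Both end at compound 3, so leaving 3-bromophenyl is expected to raise the number in this assay, more likely by a modest step than a large one. The estimated step is a 9.4-fold higher number from compound 3 to compound 4 (0.97 log units; beyond the scatter). Compound 4 is expected at 30 nM, with an estimated range of 5 nM to 300 nM.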

Compound 4, half-maximal inhibitory concentration: 1 nM
For compound 4 the middle estimate is 30-fold (1.48 log units) above the measured one; the whole stated range lies above it.
By their numbers in this assay, from the lowest: compound 4; then compound 3; then compound 2. At a limit, above all of these: compound 1.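

In this assay, a phenyl with two halogens on the sulfonyl sulfur need not raise the number, as compound 2 had suggested: the change gives a 3.2-fold lower number from compound 3 to compound 4 (0.51 log units; beyond the scatter), and also a 12-fold lower number from compound 2 to compound 4 (1.08 log units; beyond the scatter). 2,4-Dichlorophenyl also widens the gap to 2-chloropyridin-3-yl, with an at least 5000-fold lower number from compound 1 to compound 4 (3.69 log units; beyond the scatter). Compound 1 stands at a limit: the limit of > 5000 nM in this assay, at which 1 of the 4 values shown sits.

On these data alone, what 2,4-difluorophenyl, 2,4-dibromophenyl, or a methoxy group or an amine on the phenyl would give remains open. So does whether the number follows the kind of halogen or where it sits.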